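The source may hold more compounds than are shown below. What is called first, only, known or untested is meant among the compounds shown, and "the series" means these compounds.

Compound 2 `O=C1O/C(=C\Cn2cnc3cc[nH]c3c2=O)C(OCc2ccccc2)=C1OCc1ccccc1` carries a side chain that ends in a bicyclic group with one five-membered aromatic ring with 1 hetero atom and one six-membered aromatic ring with 2 hetero atoms. In a functional assay on HepG2 cells (Homo sapiens) for antiproliferative activity, read by MTT assay, with a stated time of 72 h (a lower number here means a stronger inhibitor, a higher number a weaker inhibitor), compound 2 gives > 100000 nM, which is a limit of the assay rather than a number. Compound 1 `O=C1NC(O)(CCn2cnc3ccnc(Cl)c32)C(OCc2ccccc2)=C1OCc1ccccc1` is a close relative with a saturated core. In this assay compound 1 gives > 100000 nM, again a limit. Compound 3 `O=C1NC(O)(CCn2cnc3cc[nH]c3c2=O)C(OCc2ccccc2)=C1OCc1ccccc1` has the same saturated core as compound 1 but the bicyclic group of compound 2. In this assay compound 3 gives > 100000 nM, also a limit. Going by the values given here, the one measured step that swaps these two bicyclic groups, a step that the two limits leave unreadable from compound 1 to compound 3, therefore cannot be read, because of the limit of > 100000 nM in this assay, at which 3 of the 3 values shown sit.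

Compound 4 `O=C1O/C(=C\Cn2cnc3ccnc(Cl)c32)C(OCc2ccccc2)=C1OCc1ccccc1` applies the reverse of that swap to compound 2: a group of 10 heavy atoms (6 carbon, 3 nitrogen, 1 chlorine; one five-membered aromatic ring with 2 hetero atoms, one six-membered aromatic ring with 1 hetero atom) in place of a group of 10 heavy atoms (6 carbon, 3 nitrogen, 1 oxygen; one five-membered aromatic ring with 1 hetero atom, one six-membered aromatic ring with 2 hetero atoms), on a saturated chain carbon bound to a double-bonded chain carbon. Among the compounds with values here, since the only comparable step gives no readable size, no shift beyond the scatter can be expected in this assay from this change. Compound 4 is therefore expected to sit at about 200000 nM, within the range 60000 nM to 1000000 nM, most likely reported again as a limit. The expected step from compound 2 to compound 4 is a step that the limit leaves unreadable from compound 2 to compound 4.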

Compound 4, half-maximal inhibitory concentration: > 100000 nM
Compound 4 ended at the assay's limit; the forecaster's own chance of this, stated with the estimate: 85%; the middle value is on the limit's open side.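

The step from compound 2 to compound 4 cannot be read, because both compounds sit at a limit of the assay rather than at a number: the limit of > 100000 nM in this assay, at which 4 of the 4 values shown sit.

The compounds shown leave open whether swapping these two bicyclic groups, on either core, makes any difference in this assay, and none of them gives an actual number to start from.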